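Swapping the Amide Substituent: Expected Cytotoxicity of Compound 4

The source may hold more compounds than are shown below. What is called first, only, known or untested is meant among the compounds shown, and "the series" means these compounds.

Three compounds have so far been measured in an ADME assay on PC-3 cells (Homo sapiens) for cytotoxicity, read by WST assay, tested at 100 uM; on this read-out lower numbers stand for less inhibition and higher numbers for more inhibition at the one concentration tested (going by the name of the read-out):

Compound 1 `COC(=O)c1cccc(NC(=O)C2CCCN(C(=O)c3cc(C(F)(F)F)cc(C(F)(F)F)c3)C2)c1`: 0%
Compound 2 `O=C(Nc1cccc(OCCc2ccccn2)c1)C1CCCN(C(=O)c2cc(C(F)(F)F)cc(C(F)(F)F)c2)C1`: 5%
Compound 3 `COC(=O)c1cc(-c2cccc(NC(=O)C3CCCN(C(=O)c4cc(C(F)(F)F)cc(C(F)(F)F)c4)C3)c2)co1`: 0%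

All three numbers are low, and none of the steps between them goes beyond the usual scatter. Compound 1 stands level with compound 3, the two together giving the lowest of the three numbers; the step of no change at the digits printed from compound 1 to compound 3 (within the scatter) shows no change at the digits reported, and the step of a number 5 percentage points higher from compound 1 to compound 2 (within the scatter) is also within the scatter.

Compound 4 `O=C(Nc1ccc(Cl)cc1)C1CCCN(C(=O)c2cc(C(F)(F)F)cc(C(F)(F)F)c2)C1` is the next compound to be measured. It differs from compound 1 in one place: 4-chlorophenyl in place of 3-(methoxycarbonyl)phenyl on an amide-type nitrogen. The measured steps each exchanged a group on an aromatic carbon of the same methoxycarbonyl-bearing ring, whereas here that whole ring is replaced, so they bear on the new step only loosely. Still, every change so far has left the number within the scatter, and the three values share the same low level. The step of a number 3 percentage points higher from compound 1 to compound 4 (within the scatter) is therefore expected to lie within the scatter in this assay. Compound 4 is estimated at 3%, with a range from 0% to 15%.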

Compound 4, a percentage reported as inhibition, at one concentration (the size of the read-out at that concentration, not a potency): 14%
The estimate for compound 4 lay 11 percentage points below the measured number; measured number inside the range.
By their numbers in this assay, from the lowest: compounds 1, 3, 2 and 4 (each within the scatter of the next, the first and the last beyond it).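

In this assay, the exchanges made on the aromatic ring stayed within the scatter, but replacing the whole group on the amide-type nitrogen gives a modest rise beyond it, a step of a number 14 percentage points higher from compound 1 to compound 4 (beyond the scatter) in this series. This position can therefore move the read-out, at least when 3-(methoxycarbonyl)phenyl gives way to 4-chlorophenyl, a change that also exchanges the two oxygens of the ester for a single chlorine. No measurement at hand accounts for the rise, so it stands as an observation on one pair of compounds.

From the compounds shown here alone, it remains open whether the rise comes with the chlorine or with the loss of methoxycarbonyl. A plain phenyl or a bromophenyl on that nitrogen would help to separate the two.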